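Acetogenin series: shortening the terminal diene chain

A few compounds are considered here, and "the series" means these few. Any claim that something is new, unique, unknown or untested is made for them only; others in the source may bear on it.

Measured so far:
compound 1 `C=CCC/C=C\C=C/CCCCCCCC[C@H]1CC[C@H]([C@@H]2CC[C@@H](CC(=O)O)OO2)O1` — 0.1 ug/mL
compound 2 `C=CCCC/C=C/C=C\CCCCCCCC[C@@H]1CC[C@@H]([C@@H]2CC[C@@H](CC(=O)O)OO2)O1` — 0.1 ug/mL

In a functional assay on DU-145 cells (Homo sapiens) for cytotoxicity (on this read-out higher numbers stand for weaker inhibition and lower numbers for stronger inhibition), compound 1 gives 0.1 ug/mL and compound 2 gives 0.1 ug/mL; the two values are level within the scatter. Compound 3 `C=CCC/C=C\C=C/CCCCCCCC[C@@H]1CC[C@@H]([C@@H]2CC[C@@H](CC(=O)O)OO2)O1` differs from compound 2 by a group of 6 heavy atoms (6 carbon; no ring) in place of a group of 7 heavy atoms (7 carbon; no ring), on a double-bonded chain carbon bound to a double-bonded chain carbon. With no measured step of this kind in hand, the expected step of no change at the digits printed from compound 2 to compound 3 (within the scatter) is none beyond the scatter, because compound 1 gives 0.1 ug/mL and compound 2 gives 0.1 ug/mL with only chain variation between them. Compound 3 is therefore estimated at 0.1 ug/mL, within 0.04 ug/mL to 0.25 ug/mL.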

Compound 3, half-maximal inhibitory concentration: 0.1 ug/mL
Estimate against measurement, compound 3: no gap at the digits printed; low and high end bracket the measured number.
By their numbers in this assay, from the lowest: compounds 1, 2 and 3 (each within the scatter of the next).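

In this assay, among these compounds, replacing hepta-1,6-dien-1-yl with the group of 6 carbon atoms gives no change at the digits printed from compound 2 to compound 3 (within the scatter), the first single-place reading at this double-bonded chain carbon. Changing the two saturated ring stereocentres gives no change at the digits printed from compound 1 to compound 3 (within the scatter), so this read-out does not separate these two drawn configurations: the fact that compounds 1 and 3 differ only in the configuration as drawn

As far as these compounds go, whether a longer chain, or an amine on this double-bonded chain carbon, would read the same stays open. The other stereo elements also remain untested by any single-place comparison among these compounds.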